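Methyl versus bromo on the pyridinyl ring and chemokine receptor antagonism

The source may hold more compounds than are shown below. What is called first, only, known or untested is meant among the compounds shown, and "the series" means these compounds.

Compound 3 `CC1(C)[C@@H]2CC[C@@]1(CS(=O)(=O)N1CCN(c3ccccn3)CC1)C(=O)C2` reports only a limit in a functional assay on CHO-K1 cells for antagonist activity at C-X-C chemokine receptor type 3 (Homo sapiens), read by FLIPR and calcium flux (a lower number here means a stronger inhibitor, a higher number a weaker inhibitor), namely > 31600 nM. Compound 1 `CC1(C)[C@@H]2CC[C@@]1(CS(=O)(=O)N1CCN(c3ncccc3C(F)(F)F)CC1)C(=O)C2` likewise gives only a limit, > 31600 nM. Two of the three values stand at that ceiling (the limit of > 31600 nM in this assay, at which 2 of the 3 values shown sit). Compound 2 `CC1(C)[C@@H]2CC[C@@]1(CS(=O)(=O)N1CCN(c3ccc(Br)cn3)CC1)C(=O)C2` gives 1580 nM. Compound 4 `Cc1ccc(N2CCN(S(=O)(=O)C[C@]34CC[C@H](CC3=O)C4(C)C)CC2)nc1` differs from compound 3 by methyl in place of hydrogen on an aromatic carbon. The step that bears on this is an at least 20-fold higher number from compound 2 to compound 3 (1.30 log units; beyond the scatter), which removes a substituent from the same aromatic carbon; the step of an at least 20-fold lower number from compound 1 to compound 2 (1.30 log units; beyond the scatter) also changes the pyridinyl substitution but alters two features at once. A methyl at the carbon that carries bromo in compound 2 is expected to recover part of that loss, so a lower number is expected for the step of an at least 3.9-fold lower number from compound 3 to compound 4 (0.59 log units; beyond the scatter). For compound 4 the estimate is 8000 nM, between 2000 nM and 40000 nM.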

Compound 4, half-maximal inhibitory concentration: > 31600 nM
Compound 4 was reported as a limit; the forecaster's own chance of this, stated with the estimate: 40%; middle value at least 3.9-fold (0.59 log units) from the limit.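

In this assay, methyl does not reproduce what bromo gives at this aromatic carbon, para to a large group: replacing bromo with methyl gives an at least 20-fold higher number from compound 2 to compound 4 (1.30 log units; beyond the scatter). Compound 4 is reported only as a limit, which places it with the other compounds at the ceiling: the limit of > 31600 nM in this assay, at which 3 of the 4 values shown sit. The steps from compound 3 and from compound 1 to compound 4 cannot be read, so any difference between methyl and hydrogen here remains hidden.

Going by these compounds alone, compound 2 remains the only compound with a measured number. As far as these compounds go, whether chloro, methoxy or a nitrile at this carbon would also give one remains open.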